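Swapping Dichlorophenyl for Methoxyphenyl on a Nuclear Receptor Agonist

This account rests on a few compounds, and the source may have more. Where it says the series, first, only, none or still open, it means among the compounds named here.

Of the compounds shown here, three have been tested in an assay on HepG2 cells for agonist activity at nuclear receptor subfamily 1 group I member 3 (Homo sapiens), read by a luciferase reporter, with a stated time of 23 h; on this read-out higher numbers stand for an effect only at larger amounts of compound and lower numbers for an effect already at smaller amounts. Compound 1 `Clc1ccc(CO/N=C/c2c(-c3ccc4ccccc4c3)nc3sccn23)cc1Cl` gives 380 nM. For the measured compounds named here, compound 2 `Clc1ccc(CO/N=C/c2c(-c3ccc4ccccc4c3)nc3occn23)c(Cl)c1` gives 1500 nM, the highest of the two numbers measured so far; compound 1 sits lower, and that gap lies beyond the usual scatter. For compound 3 `Clc1ccc(CO/N=C/c2c(-c3ccc(C4CCCCC4)cc3)nc3sccn23)cc1Cl` the assay reports only a limit, > 100000 nM, and no number. Compound 4 `COc1ccc(CO/N=C/c2c(-c3ccc4ccccc4c3)nc3occn23)cc1` has not yet been measured. It differs from compound 2 in one place: 4-methoxyphenyl in place of 2,4-dichlorophenyl on a saturated chain carbon bound to an oxygen on an unsaturated carbon. Going by the values given here, no pair of measured compounds shows this kind of change, so the expectation rests on the structural change alone. The step from compound 2 to compound 4 is expected to be a 3.3-fold higher number from compound 2 to compound 4 (0.52 log units; beyond the scatter), in the direction of a higher number. Compound 4 is therefore estimated to give 5000 nM, within the range 1500 nM to 30000 nM.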

Compound 4, half-maximal effective concentration: 4400 nM
Beside the measured number, compound 4's estimate is 1.1-fold (0.06 log units) above it, and the stated range covers the measured number.
By their numbers in this assay, from the lowest: compound 1; then compound 2; then compound 4. At a limit, above all of these: compound 3.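

The change from 2,4-dichlorophenyl to 4-methoxyphenyl gives a 2.9-fold higher number from compound 2 to compound 4 (0.47 log units; beyond the scatter) in this assay, so the group on this saturated chain carbon does affect the read-out. Compound 4 still gives a measured number rather than a limit, so this change does not abolish the effect. Nothing shown bears on why the number rises.

From the compounds shown here alone, both chlorines leave and a methoxy group enters in a single step, so their separate contributions stay unknown. Also open, going by these compounds, is how 4-chlorophenyl, or a phenyl ring carrying an amine or a carboxylic acid, would behave at this place.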